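An amino group added to compound 1

The compounds below may be only part of what the source reports. "The series", "measured", "known", "first", "only" and "open" are said of these compounds alone.

compound 1 `N=C(N)N/N=C/c1cccc(C(=N)N)c1` gives 9100 nM
compound 2 `N=C(N)N/N=C/c1cccc(C(N)=O)c1` gives > 184000 nM (a limit of the assay)
compound 3 `C/C(=N\N=C(N)N)c1cccc(C(=N)N)c1` gives 118000 nM

In a functional assay on T-24 cells (Homo sapiens) for antiproliferative activity (a lower number here means a stronger inhibitor, a higher number a weaker inhibitor), compound 1 has the lowest of the numbers shown, well clear of compound 3 at 118000 nM in a gap beyond the scatter. Going by the values given here, compound 4 `N=C(NN)N/N=C/c1cccc(C(=N)N)c1` has amino in place of hydrogen on an amine nitrogen as its only difference from compound 1. Among the compounds with values here, the single measured step, an at least 20-fold higher number from compound 1 to compound 2 (1.30 log units; beyond the scatter), lies on an aromatic carbon, so it bears only loosely on this change and no measured step tests that nitrogen. Given that step, a moderate move toward a higher number is expected, and the estimated step is a 2.2-fold higher number from compound 1 to compound 4 (0.34 log units; beyond the scatter) in this assay as the expected outcome. For compound 4 the expected value is 20000 nM (estimated range 5000 nM to 70000 nM) .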

Compound 4, half-maximal inhibitory concentration: 25000 nM
For compound 4 the middle estimate is 1.3-fold (0.10 log units) below the measured one, and the stated range covers the measured number.
By their numbers in this assay, from the lowest: compound 1; then compound 4; then compound 3. At a limit, above all of these: compound 2.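

Amino in place of hydrogen on this amine nitrogen gives a 2.7-fold higher number from compound 1 to compound 4 (0.44 log units; beyond the scatter) in this assay, the first measured change at this position. The position therefore accepts the added amino group at a modest cost, and compound 1 remains the lowest of the compounds shown. Nothing measured here accounts for the size of this step. Going by these compounds, whether a methyl group or a hydroxyl group on the same nitrogen would give a similar step remains open, as does whether amino would have the same effect on the core of compound 3.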